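The compounds below may be only part of what the source reports. "The series", "measured", "known", "first", "only" and "open" are said of these compounds alone.

Compound 1 `Cc1nc2c(OCc3ccccc3)cccn2c1/N=C/N(C)C`: 0%
Compound 2 `CCCNc1c(C)nc2c(OCc3ccccc3)cccn12`: 68%

In a functional assay on the whole organism with Canis familiaris (Canis lupus familiaris) as the target, at a dose of 8 mg/kg by the oral route (a higher number here means a stronger effect of the compound at the dose given, a lower number a weaker effect), compound 2 gives 68%, the higher of the two numbers, while compound 1 gives 0%. Compound 3 `Cc1nc2c(OCc3ccccc3)cccn2c1N(C)C` differs from compound 2 by dimethylamino in place of propylamino on an aromatic carbon. Among the measured compounds shown here, the one measured step at this same place, a number 68 percentage points higher from compound 1 to compound 2 (beyond the scatter), was large, so this position matters. Compound 3 keeps a small group there but loses the hydrogen-bond donor that compound 2 carries, so a sizeable drop is expected for compound 3: a step of a number 43 percentage points lower from compound 2 to compound 3 (beyond the scatter). Compound 3 is therefore estimated at 25%, in the range 0% to 60%.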

Compound 3, a percentage reported as inhibition, in the whole organism at one dose (the size of the read-out at that dose, not a potency): 72%
For compound 3 the middle estimate is 47 percentage points below the measured one; measured number outside the range, above it.
By their numbers in this assay, from the lowest: compound 1; then compounds 2 and 3 (each within the scatter of the next).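

In this assay, the step of a number 4 percentage points higher from compound 2 to compound 3 (within the scatter) shows that, at this carbon, dimethylamino serves as well as propylamino, even though it has no hydrogen-bond donor. The step of a number 72 percentage points higher from compound 1 to compound 3 (beyond the scatter) shows that the loss seen with compound 1 does not extend to this second small amine, so it belongs to the group in compound 1 rather than to every nitrogen-linked group here. Nothing available explains these numbers. Still open, on these data alone, is whether a plain primary amine or a longer chain such as hexylamino would keep this effect. As far as these compounds go, a cyclic amine such as piperidine is equally open.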